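A few compounds are considered here, and "the series" means these few. Any claim that something is new, unique, unknown or untested is made for them only; others in the source may bear on it.

Compound 1 `C=C1CCCC(C)(C)C1CC[C@]1(C)CC[C@@H]([C@@H](C)C(=O)O)OO1`: in a functional assay on NCI-H226 cells (Homo sapiens) for inhibition (a higher number here means a weaker inhibitor of growth, a lower number a stronger inhibitor of growth), compound 1 gives only a limit, > 10000 nM.
Compound 2 `C=C1CCCC(C)(C)C1CC[C@]1(C)CC[C@H]([C@@H](C)C(=O)OC)OO1`: in this assay compound 2 gives 6170 nM.
Compound 3 `C=C1CCC[C@H]2[C@](C)(CC[C@]3(C)CC[C@@H]([C@@H](C)C(=O)O)OO3)[C@@H](C)CC[C@]12C`: in this assay compound 3 gives only a limit, > 5000 nM.

Compound 1 therefore stands at a limit rather than at a number, and of the other two values shown one is also a limit, leaving a single measured number, from compound 2. Compound 4 `C=C1CCCC(C)(C)C1CC[C@@]1(C)CC[C@H]([C@@H](C)C(=O)O)OO1` keeps every atom and bond of compound 1; (the two compounds have the same atoms and bonds; at least one stereo element is drawn with a configuration in one of them and without one in the other: 2 of 4 stereo elements differ; a stereocentre at a saturated ring carbon is drawn R in compound 1 and S in compound 4; a stereocentre at a saturated ring carbon is drawn S in compound 1 and R in compound 4). Among the compounds with values here, no measured pair shows what such a change does here, so no step beyond the scatter is expected in this assay in either direction. Compound 4 is expected to give 10000 nM, between 3000 nM and 30000 nM, and the step of a number no higher from compound 1 to compound 4 (the limit leaves the size open) is expected to be small, with the result most likely reported once more only as a limit.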

Compound 4, concentration for 50% growth inhibition: 12500 nM
Compound 4: middle estimate off by 1.3-fold (0.10 log units), on the low side; the range from low to high includes it.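

Within the data shown here, no step from compound 1 to compound 4 can be read. Compound 1 stands only at a limit: the limit of > 10000 nM in this assay, at which 1 of the 4 values shown sits.

The compounds shown leave open how far the configuration at the two differing saturated ring carbons changes growth inhibition in this assay.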